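Compound 3 to compound 4: trifluoromethyl out, dimethylamino in

This account rests on a few compounds, and the source may have more. Where it says the series, first, only, none or still open, it means among the compounds named here.

Three compounds on the shared core have numbers in an ADME assay on A549 cells (Homo sapiens) for cytotoxicity, read by resazurin assay, with a stated time of 48 h; on this read-out higher numbers stand for lower toxicity in this test and lower numbers for higher toxicity in this test. Compound 1 `CCNc1ccc(NC(=O)c2cc(Cl)ccc2O)c(Cl)c1` gives 30200 nM, compound 2 `O=C(Nc1ccc(NCc2ccc(Cl)cc2)cc1Cl)c1cc(Cl)ccc1O` gives 59700 nM and compound 3 `O=C(Nc1ccc(NCc2ccc(C(F)(F)F)cc2)cc1Cl)c1cc(Cl)ccc1O` gives 62700 nM. Compound 3 stands clear only of compound 1, with a 2.1-fold higher number from compound 1 to compound 3 (0.32 log units; beyond the scatter), a modest step. It cannot be separated from compound 2, with a 1.1-fold higher number from compound 2 to compound 3 (0.02 log units; within the scatter).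

Compound 4 `CN(C)c1ccc(CNc2ccc(NC(=O)c3cc(Cl)ccc3O)c(Cl)c2)cc1` follows from compound 3 by dimethylamino in place of trifluoromethyl on an aromatic carbon, para to a large group. The closest evidence is the swap of chloro for trifluoromethyl, a 1.1-fold higher number from compound 2 to compound 3 (0.02 log units; within the scatter). The larger replacement, a 2.0-fold higher number from compound 1 to compound 2 (0.30 log units; within the scatter), also stays small. Within the data shown here, no measured compound carries dimethylamino, so the range is kept wide. No step beyond the scatter is expected, and the estimated change is a 1.3-fold lower number from compound 3 to compound 4 (0.10 log units; within the scatter). The estimated value for compound 4 is 50000 nM, with an expected range of 25000 nM to 90000 nM.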

Compound 4, half-maximal cytotoxic concentration: 24500 nM
Beside the measured number, compound 4's estimate is 2.0-fold (0.31 log units) above it; measured number below the stated range.
By their numbers in this assay, from the lowest: compounds 4, 1, 2 and 3 (each within the scatter of the next, the first and the last beyond it).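

At this aromatic carbon, para to a large group, the choice of substituent now separates compounds in this assay: dimethylamino gives a 2.6-fold lower number from compound 3 to compound 4 (0.41 log units; beyond the scatter) and a 2.4-fold lower number from compound 2 to compound 4 (0.39 log units; beyond the scatter), whereas the exchange between chloro and trifluoromethyl gave no readable change. The 4-(dimethylamino)phenyl group in place of methyl gives a 1.2-fold lower number from compound 1 to compound 4 (0.09 log units; within the scatter), so a substituted phenyl at this chain carbon does not in itself raise the number, with compound 4 going against the rise seen for compound 3. Nothing available bears on the reason for this shift.

From the compounds shown here alone, with a single nitrogen-bearing substituent at this carbon, it remains open whether the shift belongs to dimethylamino alone or extends to other groups. A primary amine, a methoxy group or a morpholine at the same carbon would test that.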